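Swapping nitro for methoxycarbonyl on a benzyl oxadiazolone

This account rests on a few compounds, and the source may have more. Where it says the series, first, only, none or still open, it means among the compounds named here.

Measured compounds:
- compound 1, `COc1nn(Cc2cccc([N+](=O)[O-])c2)c(=O)o1`, 7%
- compound 2, `COc1nn(Cc2ccc([N+](=O)[O-])cc2)c(=O)o1`, 18%
- compound 3, `COc1nn(Cc2ccc(N)cc2)c(=O)o1`, 34%

These three share one core and differ only in the group on the benzyl ring. In an assay on COS-7 cells for inhibition of Fatty-acid amide hydrolase 1 (Homo sapiens), read by scintillation counting, with a stated time of 10 min, tested at 10 uM (on this read-out lower numbers stand for less inhibition and higher numbers for more inhibition at the one concentration tested (going by the name of the read-out)), compound 1 gives the lowest number of the three, with compound 2 next and compound 3 furthest away, both beyond the scatter. The unmeasured compound 4, `COC(=O)c1cccc(Cn2nc(OC)oc2=O)c1`, differs from compound 1 by methoxycarbonyl in place of nitro on an aromatic carbon. Among the measured compounds shown here, no measured step makes this same change. For the measured compounds named here, the only step that alters the group on the ring is a number 16 percentage points higher from compound 2 to compound 3 (beyond the scatter), so exchanging the nitro group has so far moved the number only modestly upward. A small rise is therefore expected, a number 8 percentage points higher from compound 1 to compound 4 (within the scatter). Compound 4 is estimated at 15%, between 0% and 35%.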

Compound 4, a percentage reported as inhibition, at one concentration (the size of the read-out at that concentration, not a potency): 20%
Compound 4: the middle estimate sits 5 percentage points below what was measured; the range from low to high includes it.
By their numbers in this assay, from the lowest: compound 1; then compounds 2 and 4 (each within the scatter of the next); then compound 3.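

Methoxycarbonyl in place of nitro at this ring position gives a number 13 percentage points higher from compound 1 to compound 4 (beyond the scatter) in this assay. The earlier step replaced nitro elsewhere on the ring, so this shows that replacing nitro can also raise the number at this position, and with a group other than amino. Nothing measured here explains the rise. From the compounds shown here alone, whether an amine or a carboxylic acid at this same position would go further remains open. Going by these compounds, each number comes from a single concentration, so how potency differs between the compounds is also open.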